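A few compounds are considered here, and "the series" means these few. Any claim that something is new, unique, unknown or untested is made for them only; others in the source may bear on it.

Compound 1 `COc1ccc(-c2cc(NNC(=O)Nc3cc(Cl)nc(Cl)c3)nc3c2cnn3C)cc1` gives 18500 nM
Compound 2 `COc1cc(NC(=O)NNc2cc(-c3ccccc3)c3cnn(C)c3n2)cc(Cl)n1` gives 28700 nM
Compound 3 `Cc1nn(C)c2nc(NNC(=O)Nc3cc(Cl)nc(Cl)c3)cc(C3CC3)c12` gives 80800 nM

All three numbers come from a functional assay on SW620/5-FU cells (Homo sapiens) for cytotoxicity, read by MTT assay, with a stated time of 48 h, in the presence of a further agent that is not named here (on this read-out higher numbers stand for an effect only at larger amounts of compound and lower numbers for an effect already at smaller amounts), and they place compound 1 at the low end, within the scatter of compound 2. Compound 3 has a higher number than compound 1, beyond the scatter. Compound 4 `COc1ccc(-c2cc(NNC(=O)Nc3cc(Cl)nc(OC(C)C)c3)nc3c2cnn3C)cc1` is still unmeasured. It keeps the core of compound 1 but has isopropoxy in place of chloro on an aromatic carbon. Within the data shown here, no measured pair here differs in one place only, so the data offer no direct guide. No clear change in this assay is expected, and the expected step is a 1.1-fold higher number from compound 1 to compound 4 (0.03 log units; within the scatter) and stays within the scatter. For compound 4 the estimated value is 20000 nM with an expected range from 7000 nM to 60000 nM in this estimate.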

Compound 4, half-maximal effective concentration: 47100 nM
The estimate for compound 4 lay 2.4-fold (0.37 log units) below the measured number; measured number inside the range.
By their numbers in this assay, from the lowest: compounds 1, 2, 4 and 3 (each within the scatter of the next, the first and the last beyond it).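

Among these compounds, this is the first comparison in the set that differs in one place only: in this assay, isopropoxy in place of chloro gives a 2.5-fold higher number from compound 1 to compound 4 (0.41 log units; beyond the scatter), a modest step beyond the scatter. It shows that this position, next to the ring nitrogen, is sensitive to what sits on it, and that with isopropoxy there the effect needs more compound. No measurement here explains the step. Open, on these data alone, is whether ethoxy or a dimethylamino group at this place would stay closer to compound 1. Also open, as far as these compounds go, is whether the same swap would act alike on compound 3.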